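Trifluoromethoxy analogue in the hydrazide series

A few compounds are considered here, and "the series" means these few. Any claim that something is new, unique, unknown or untested is made for them only; others in the source may bear on it.

For the measured compounds named here, compound 3 `O=C(NNc1nncc2ccccc12)C1CC1c1ccc(OCC(F)(F)F)cc1` stands as the lowest of the two numbers so far in a functional assay on SK-MEL cells (Homo sapiens) for inhibition, read by MTT assay, with a stated time of 72 h (on this read-out lower numbers stand for stronger inhibition and higher numbers for weaker inhibition), with a value of 29000 nM. Compound 2 `COc1ccc(C2CC2C(=O)NNc2nncc3ccccc23)cc1` gives 68000 nM in this assay. Compound 1 `O=C(NNC(=O)C1CC1c1ccc(OC(F)(F)F)cc1)c1ccncc1` carries a different acyl part, and in this assay compound 1 has "not determined" (no result reported). Going by the values given here, the single one-point step measured, a 2.3-fold lower number from compound 2 to compound 3 (0.37 log units; beyond the scatter), came from adding fluorines at the chain on the aryl oxygen and was modest. Compound 4 `O=C(NNc1nncc2ccccc12)C1CC1c1ccc(OC(F)(F)F)cc1` differs from compound 3 by trifluoromethyl in place of 2,2,2-trifluoroethyl on an oxygen on an aromatic ring. Among the compounds with values here, no measured pair covers a change of chain length on this oxygen, so the only bearing step is the fluorination one, and it shows the region tolerates variation without a large swing. The expected step in this assay is therefore a 1.0-fold higher number from compound 3 to compound 4 (0.01 log units; within the scatter), with no clear direction beyond the scatter. For compound 4 the estimated value in this assay is 30000 nM, with a range from 10000 nM to 90000 nM.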

Compound 4, half-maximal inhibitory concentration: 29000 nM
For compound 4 the middle estimate is 1.0-fold (0.01 log units) above the measured one; measured number inside the range.
By their numbers in this assay, from the lowest: compounds 3 and 4 (each within the scatter of the next); then compound 2.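

In this assay, trifluoromethyl in place of 2,2,2-trifluoroethyl on the oxygen gives no change at the digits printed from compound 3 to compound 4 (within the scatter), so the 2,2,2-trifluoroethoxy and trifluoromethoxy groups cannot be told apart here, and this change of chain shows no effect on the read-out. Trifluoromethyl in place of methyl on the same oxygen gives a 2.3-fold lower number from compound 2 to compound 4 (0.37 log units; beyond the scatter), a second modest step of the same size as a 2.3-fold lower number from compound 2 to compound 3 (0.37 log units; beyond the scatter), so among these three compounds the two fluorinated groups read alike and the methoxy compound stands apart. No measurement at hand gives a reason for this result.

Open, on these data alone, is whether an ethoxy group, without fluorine, would read with compound 2 or with compound 3 and compound 4, which would separate the fluorines from the chain. Also open, as far as these compounds go, is how a longer chain, an amine or a carboxylic acid at this place would read.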